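Swapping a halogenated ring for an acetamide on a weak series

A few compounds are considered here, and "the series" means these few. Any claim that something is new, unique, unknown or untested is made for them only; others in the source may bear on it.

Compound 1, `CN(c1ncccc1CNc1nc(Nc2ccc3c(c2)CC(=O)N3)nc2[nH]ccc12)S(C)(=O)=O`, gives 52800 nM in a functional assay on SMMC-7721 cells (Homo sapiens) for inhibition, read by MTT assay, with a stated time of 48 h; a lower number here means a stronger inhibitor, a higher number a weaker inhibitor.
Compound 2, `Cc1cc2c(NCc3cccnc3N(C)S(C)(=O)=O)nc(Nc3ccc4c(c3)CC(=O)N4)nc2[nH]1`, gives > 100000 nM in this assay; this is a limit of the assay, not a number.
Compound 3, `CN(c1ncccc1CNc1nc(Nc2ccc(F)c(Cl)c2)nc2[nH]cc(F)c12)S(C)(=O)=O`, gives > 100000 nM in this assay; this too is a limit of the assay, not a number.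

All three compounds share the same core and sit at the weak end of what this assay can resolve. Within the data shown here, the single measured step, an at least 1.8-fold higher number from compound 1 to compound 2 (0.27 log units; that floor lies within the scatter), concerns a methyl on the shared core and stays within the scatter. Compound 3 stands at the limit of > 100000 nM in this assay, at which 2 of the 3 values shown sit, so only a floor is known for it. Compound 4, `CC(=O)Nc1cccc(Nc2nc(NCc3cccnc3N(C)S(C)(=O)=O)c3c(F)c[nH]c3n2)c1`, differs from compound 3 by 3-acetamidophenyl in place of 3-chloro-4-fluorophenyl on a nitrogen on an aromatic ring. Among the measured compounds shown here, no measured step covers this exchange, so the expectation rests on where compound 3 stands. Compound 4 is expected near 90000 nM, somewhere between 20000 nM and 300000 nM. The expected step of an at least 1.1-fold lower number from compound 3 to compound 4 (0.04 log units; that floor lies within the scatter) is accordingly small, with no direction beyond the scatter.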

Compound 4, half-maximal inhibitory concentration: 16000 nM
Beside the measured number, compound 4's estimate is 5.6-fold (0.75 log units) above it; measured number outside the range, below it.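

In this assay, replacing 3-chloro-4-fluorophenyl with 3-acetamidophenyl on a nitrogen on an aromatic ring gives an at least 6.2-fold lower number from compound 3 to compound 4 (0.79 log units; beyond the scatter). This shows that the group at this position can move the read-out beyond the scatter, which the methyl step on the shared core did not show. As far as these compounds go, the true size of the change remains unknown, and only its floor can be read, because compound 3 has only a limit: the limit of > 100000 nM in this assay, at which 2 of the 4 values shown sit.

The compounds shown do not separate the gain from adding the acetamide from the effect of losing the chlorine and fluorine. A plain phenyl or a 3-aminophenyl on this nitrogen would help to tell these apart, while a carboxylic acid in place of the acetamide would test whether the amide itself matters.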